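A few compounds are considered here, and "the series" means these few. Any claim that something is new, unique, unknown or untested is made for them only; others in the source may bear on it.

Compound 1 `COc1cc(/C=C/C(C)=O)ccc1OCc1cn(-c2ccc(C)cc2)nn1` gives 76600 nM in a functional assay on HCT-116 cells (Homo sapiens) for antiproliferative activity, read by MTT assay, with a stated time of 48 h; a higher number here means a weaker inhibitor, a lower number a stronger inhibitor.
Compound 2 `CCOC(=O)c1ccc(-n2cc(COc3ccc(/C=C/C(C)=O)cc3OC)nn2)cc1` gives 78900 nM in this assay.

Compound 2 has the highest of the two numbers shown, with compound 1 as its nearest neighbour; the step of a 1.0-fold higher number from compound 1 to compound 2 (0.01 log units; within the scatter) lies within the scatter, so the two compounds cannot be ordered on these data. Compound 3 `COc1cc(/C=C/C(C)=O)ccc1OCc1cn(-c2ccc(-c3ccccc3)cc2)nn1` differs from compound 2 by phenyl in place of ethoxycarbonyl on an aromatic carbon. Within the data shown here, the only measured step that bears on this position is the one from compound 1 to compound 2, where a change of the same group on the same aromatic carbon left the number unchanged within the scatter. On that basis no step beyond the scatter is expected from compound 2 to compound 3 in this assay; the expected step is a 1.1-fold lower number from compound 2 to compound 3 (0.05 log units; within the scatter). Compound 3 is therefore estimated at 70000 nM, within a range from 25000 nM to 200000 nM.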

Compound 3, half-maximal inhibitory concentration: 65300 nM
The estimate for compound 3 lay 1.1-fold (0.03 log units) above the measured number; low and high end bracket the measured number.
By their numbers in this assay, from the lowest: compounds 3, 1 and 2 (each within the scatter of the next).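

In this assay, phenyl in place of ethoxycarbonyl gives a 1.2-fold lower number from compound 2 to compound 3 (0.08 log units; within the scatter), and phenyl in place of methyl gives a 1.2-fold lower number from compound 1 to compound 3 (0.07 log units; within the scatter). The earlier pair covered only methyl and ethoxycarbonyl, whereas this position, para to a large group, now also carries a group with a six-membered aromatic ring of carbon only. Even with that ring in place and the two hydrogen-bond acceptors of ethoxycarbonyl gone, the three compounds cannot be ordered, so this change of group has not yet shown any effect on the number here.

Nothing given here explains why these three groups read alike. As far as these compounds go, whether an amine, a carboxylic acid or a longer chain at this position would move the number beyond the scatter remains open, as does the effect of changes elsewhere on the shared core.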